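Bromine on the Phenyl Ring: An Expected Small Effect

The source may hold more compounds than are shown below. What is called first, only, known or untested is meant among the compounds shown, and "the series" means these compounds.

Of the compounds shown here, two have been measured in a functional assay on HepG2 cells (Homo sapiens) for inhibition, read by MTT assay, with a stated time of 48 h; a higher number here means a weaker inhibitor, a lower number a stronger inhibitor. Compound 1 `COc1cc(/C=N/Nc2nc(-c3ccc(F)c(F)c3)cs2)c(Br)c(Br)c1OC` gives 49700 nM in this assay. Compound 2 `COc1cc(/C=N/Nc2nc(-c3ccccc3)cs2)c(Br)c(Br)c1OC` differs from it only in carrying a plain phenyl group where compound 1 carries a 3,4-difluorophenyl group; in this assay compound 2 gives 33600 nM. The step of a 1.5-fold lower number from compound 1 to compound 2 (0.17 log units; within the scatter) lies within the usual scatter, so the two compounds cannot be told apart on these numbers; compound 2 stands alongside compound 1 rather than ahead of it.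

Compound 3 `COc1cc(/C=N/Nc2nc(-c3cccc(Br)c3)cs2)c(Br)c(Br)c1OC` is not yet measured. It differs from compound 2 by bromo in place of hydrogen on an aromatic carbon, so the phenyl group becomes a 3-bromophenyl group. Among the compounds with values here, the only measured step that bears on this, the one between compound 1 and compound 2, also concerns halogen substitution on the same six-membered ring, and it stayed within the scatter. On that basis, the change in this assay from compound 2 to compound 3 is expected to be small, a 1.0-fold higher number from compound 2 to compound 3 (0.02 log units; within the scatter), with no direction favoured beyond the scatter. Compound 3 is therefore estimated at 35000 nM in this assay, with a range from 15000 nM to 80000 nM.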

Compound 3, half-maximal inhibitory concentration: > 100000 nM
Compound 3: a limit, no number; the forecaster's own chance of this, stated with the estimate: 10%; middle value at least 2.8-fold (0.45 log units) from the limit.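

Compound 3 stands at a limit of the assay and not at a number: the limit of > 100000 nM in this assay, at which 1 of the 3 values shown sits.

In this assay, a single bromo in place of hydrogen, the change that turns phenyl into 3-bromophenyl, gives an at least 2.9-fold higher number from compound 2 to compound 3 (0.47 log units; beyond the scatter), so a halogen change on this ring can move the result beyond the scatter, something the step between compound 1 and compound 2 did not show. The comparison with the 3,4-difluorophenyl group is less firm, since it reads an at least 2.0-fold higher number from compound 1 to compound 3 (0.30 log units; that floor lies within the scatter), and on that floor alone compound 3 is not separated from compound 1.

Open, on these data alone, is whether chloro, methyl, an amine or a carboxylic acid on this same carbon would shift the number as bromo does, or whether the shift belongs to bromo alone. Also open, as far as these compounds go, are how far the true number for compound 3 lies from those of the other two compounds, and whether bromo on a different carbon of this ring would act in the same way.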